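This account rests on a few compounds, and the source may have more. Where it says the series, first, only, none or still open, it means among the compounds named here.

- Compound 1 `O=C(CN1CCN(c2nnc(Cc3ccncc3)c3ccccc23)CC1)Nc1cccc(Br)c1`: 1.7 nM
- Compound 2 `O=C(CN1CCN(c2nnc(Cc3ccncc3)c3ccccc23)CC1)Nc1cccc(F)c1`: 4.4 nM
- Compound 3 `O=C(CN1CCN(c2nnc(Cc3ccccc3)c3ccccc23)CC1)Nc1cc(C(F)(F)F)ccc1Cl`: 19500 nM
- Compound 4 `O=C(CN1CCN(c2nnc(Cc3ccncc3)c3ccccc23)CC1)Nc1ccc(F)c(Cl)c1`: not yet measured

In a functional assay on MDA-MB-231 cells (Homo sapiens) for cytotoxicity, read by MTT assay, with a stated time of 72 h (a lower number here means a stronger inhibitor, a higher number a weaker inhibitor), compound 2 holds the second highest of the three numbers, with compound 1 lower and compound 3 far higher. Compound 4 carries 3-chloro-4-fluorophenyl in place of 3-fluorophenyl on an amide-type nitrogen. Among the measured compounds shown here, only one measured step bears on this change: fluoro in place of bromo on an aromatic carbon gave a 2.6-fold higher number from compound 1 to compound 2 (0.41 log units; beyond the scatter). A similarly modest step toward a lower number is therefore expected in this assay, possibly within the scatter. The estimate implies an expected 1.5-fold lower number from compound 2 to compound 4 (0.17 log units; within the scatter) at its centre. For compound 4 the estimated value is 3 nM, with an expected range of 0.8 nM to 12 nM.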

Compound 4, half-maximal inhibitory concentration: 4 nM
The estimate for compound 4 lay 1.3-fold (0.12 log units) below the measured number, within the range that was stated.
By their numbers in this assay, from the lowest: compound 1; then compounds 4 and 2 (each within the scatter of the next); then compound 3.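

In this assay, 3-chloro-4-fluorophenyl in place of 3-fluorophenyl on the amide-type nitrogen gave a 1.1-fold lower number from compound 2 to compound 4 (0.04 log units; within the scatter) and so added a chlorine with no change beyond the scatter. Set against 3-bromophenyl, the same group gave a 2.4-fold higher number from compound 1 to compound 4 (0.37 log units; beyond the scatter) and remained a modest step. Nothing measured here gives a reason for either step. Still open, on these data alone, is whether an amine or a carboxylic acid on this phenyl ring would keep the number as low. Whether a methoxy group would do so is equally unsettled.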